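Swapping the Group on the Aromatic Nitrogen

This account rests on a few compounds, and the source may have more. Where it says the series, first, only, none or still open, it means among the compounds named here.

Compound 1 `C/C=C/n1cc(/C=C/C(=O)CC(=O)C(=O)OCC)c2ccccc21` gives > 40 uM in an assay on isolated protein for inhibition of DNA nucleotidylexotransferase (Homo sapiens), read by scintillation counting, with a stated time of 10 min (on this read-out lower numbers stand for stronger inhibition and higher numbers for weaker inhibition), a limit of the assay rather than a number.
Compound 2 `CCOC(=O)C(=O)CC(=O)/C=C/c1cn(-c2ccc(Cl)cc2)c2ccccc12` gives > 40 uM in this assay, likewise a limit of the assay.

Because both values are limits, the step that the two limits leave unreadable from compound 1 to compound 2 cannot be read. Compound 2 therefore stands only at the limit, as the limit of > 40 uM in this assay, at which 2 of the 2 values shown sit, records. Compound 3 `CCOC(=O)C(=O)CC(=O)/C=C/c1cn(Cc2ccc(C#N)cc2)c2ccccc12` carries 4-cyanobenzyl in place of 4-chlorophenyl on an aromatic nitrogen. Within the data shown here, no measured step bears on this change, since the only one, a step that the two limits leave unreadable from compound 1 to compound 2, is unreadable, so no size or direction can be taken from the data. Compound 3 is expected to sit near the same limit, with an estimated value of 50 uM (range 15 uM to 200 uM), an expected step that the limit leaves unreadable from compound 2 to compound 3 that cannot be called a change beyond the scatter.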

Compound 3, concentration for 50% inhibition: > 40 uM
Compound 3 ended at the assay's limit; the forecaster's own chance of this, stated with the estimate: 70%; the middle value is on the limit's open side.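

No step can be read among compound 1, compound 2 and compound 3, since each value is only a limit of the assay: the limit of > 40 uM in this assay, at which 3 of the 3 values shown sit. As far as these compounds go, whether any group on the aromatic nitrogen can bring a measurable value in this assay stays open.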